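A few compounds are considered here, and "the series" means these few. Any claim that something is new, unique, unknown or untested is made for them only; others in the source may bear on it.

Working notes on the series. Compound 2 `Cc1ccoc1-c1ccccc1OCC1=NCCN1` carries a 3-methylfuran-2-yl on an aromatic carbon of the shared core. In a functional assay for activation of Alpha-1D adrenergic receptor (Homo sapiens), read by calcium flux (on this read-out lower numbers stand for an effect already at smaller amounts and higher numbers for an effect only at larger amounts of compound), compound 2 gives < 100000 nM, which is a limit of the assay and not a number. Going by the values given here, compound 1 `c1ccc(-c2cnccn2)c(OCC2=NCCN2)c1` is the only other measured compound; in this assay compound 1 gives < 100000 nM, again only a limit. The step that the two limits leave unreadable from compound 1 to compound 2 cannot be sized, since both values sit at the limit of < 100000 nM in this assay, at which 2 of the 2 values shown sit. Compound 3 `Cc1ccc(-c2ccccc2OCC2=NCCN2)s1` differs from compound 2 in one place: 5-methylthiophen-2-yl in place of 3-methylfuran-2-yl on an aromatic carbon. Among the compounds with values here, the single measured step concerns a different change and is unreadable, so no direction or size for the new step follows from it. For compound 3 the expected step is a step that the limit leaves unreadable from compound 2 to compound 3, nothing beyond the scatter. Compound 3 is estimated at 30000 nM, with a range from 3000 nM to 100000 nM, and most likely the assay will again report only a limit.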

Compound 3, half-maximal effective concentration: < 100000 nM
Compound 3 ended at the assay's limit (the forecaster's own chance of this, stated with the estimate: 70%); the middle value lies beyond the limit too.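

No step among compound 1, compound 2 and compound 3 can be read in this assay, since all three values are limits and not numbers: the limit of < 100000 nM in this assay, at which 3 of the 3 values shown sit.

The compounds shown leave open whether pyrazin-2-yl, 3-methylfuran-2-yl and 5-methylthiophen-2-yl differ at all on this read-out, and by how much.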